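The source may report more compounds than this note shows. Statements on the series, on what has been measured and on what is new or still open speak of the compounds shown alone.

Compound 1 `Cc1n[nH]c2c1C(c1ccc(N(C)C)cc1)C(C(=O)NNC(N)=S)=C(N)N2`: 49000 nM
Compound 2 `Cc1n[nH]c2c1C(c1ccc(N(C)C)cc1)C(C(=O)NNc1cc([N+](=O)[O-])ccc1[N+](=O)[O-])=C(N)N2`: 51200 nM

Both values come from an ADME assay on WISH cells (Homo sapiens) for cytotoxicity, read by MTT assay, with a stated time of 48 h; on this read-out higher numbers stand for weaker inhibition and lower numbers for stronger inhibition. Compound 1 has a single measured neighbour, compound 2, and the two numbers lie within the scatter of each other, so neither can be ranked above the other.

Compound 3 `Cc1n[nH]c2c1C(c1ccc(N(C)C)cc1)C=C(N)N2` is still to be measured in this assay. Its difference from compound 1 is this: a hydrogen atom in place of a group of 7 heavy atoms (2 carbon, 3 nitrogen, 1 oxygen, 1 sulfur; no ring), on a double-bonded ring carbon. The change lies on a double-bonded ring carbon, next to the ring atom that bears a 4-(dimethylamino)phenyl group.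

For the measured compounds named here, only one measured step bears on it. That step, a 1.0-fold higher number from compound 1 to compound 2 (0.02 log units; within the scatter), exchanged a group on an amine nitrogen and stayed within the scatter. Going by the values given here, it shows tolerance to a change at the far end of the group, but no measured compound lacks the whole group, so the evidence is indirect. No shift beyond the scatter is therefore expected in this assay, though the uncertainty is wide. The expected change is a 1.1-fold higher number from compound 1 to compound 3 (0.05 log units; within the scatter). For compound 3 the estimated value is 55000 nM, with an expected range from 20000 nM to 150000 nM.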

Compound 3, half-maximal inhibitory concentration: 21600 nM
Beside the measured number, compound 3's estimate is 2.5-fold (0.41 log units) above it; measured number inside the range.
By their numbers in this assay, from the lowest: compound 3; then compounds 1 and 2 (each within the scatter of the next).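

In this assay the exchange of the whole group on the double-bonded ring carbon for a hydrogen atom gives a 2.3-fold lower number from compound 1 to compound 3 (0.36 log units; beyond the scatter) and is modest but beyond the scatter. The earlier pair had tested only an exchange on the amine nitrogen within this group, and that left the numbers within the scatter of each other, whereas this step shows that the group as a whole can go and that the number then falls, so the group is not required for the inhibition seen on these cells. Nothing measured here explains the shift.

The compounds shown leave open whether the shift follows from the loss of the entire group or of only part of it, and a carboxylic acid or a primary amide on the same ring carbon would help to separate these two readings. They also leave open whether the same exchange would give a similar step with another group in place of the 4-(dimethylamino)phenyl group, since this change is read here in a single pair.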